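The source may report more compounds than this note shows. Statements on the series, on what has been measured and on what is new or still open speak of the compounds shown alone.

Measured in a physicochemical assay for lipophilicity, measured as octanol-water partition, at pH 7.4; on this read-out lower numbers stand for lower lipophilicity and higher numbers for higher lipophilicity:
- compound 1 `CC(C)c1noc(N2CCC(Oc3cc(N4CCc5cc([S+]([O-])CCO)ccc54)ncn3)CC2)n1`: 2.7
- compound 2 `CC(C)SC(=O)N1CCC(Oc2cc(N3CCc4cc(S(C)(=O)=O)ccc43)ncn2)CC1`: 3.6
- compound 3 `CC(C)c1noc(N2CCC(Oc3cc(N4CCc5cc(S(C)(=O)=O)ccc54)ncn3)CC2)n1`: 3.1

Among these three, compound 3 stands second highest at 3.1, with compound 1 below it and compound 2 above it, both gaps beyond the scatter. Compound 4 `CC(C)OC(=O)N1CCC(Oc2cc(N3CCc4cc(S(C)(=O)=O)ccc43)ncn2)CC1` comes from compound 3 by a single change, isopropoxycarbonyl in place of 3-isopropyl-1,2,4-oxadiazol-5-yl on an amine nitrogen in a ring.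

The measured step that bears on this is a number 0.50 log units lower from compound 2 to compound 3 (beyond the scatter), a modest one at the same nitrogen. Compound 2 carries (isopropylsulfanyl)carbonyl there, which differs from the entering group by having sulfur where isopropoxycarbonyl has oxygen. Among the compounds with values here, no measured pair shows what that exchange does on its own. The other step, a number 0.40 log units higher from compound 1 to compound 3 (beyond the scatter), concerns a change on an aromatic carbon and not this nitrogen, so it offers little guidance. Compound 4 is therefore expected to fall near compound 3, on the side towards compound 2, with no shift beyond the scatter. The expected step is a number 0.20 log units higher from compound 3 to compound 4 (within the scatter). The estimate for compound 4 is 3.3, with an expected range from 2.9 to 3.7.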

Compound 4, distribution coefficient: 3.1
For compound 4 the middle estimate is 0.20 log units above the measured one; the range from low to high includes it.
By their numbers in this assay, from the lowest: compound 1; then compounds 3 and 4 (each within the scatter of the next); then compound 2.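

In this assay, isopropoxycarbonyl in place of 3-isopropyl-1,2,4-oxadiazol-5-yl on an amine nitrogen in a ring gives no change at the digits printed from compound 3 to compound 4 (within the scatter), so the group with no ring and the group with one five-membered aromatic ring cannot be told apart on this read-out. Within the data shown here, the exchange of sulfur for oxygen, which no earlier pair isolated, can now be read, as isopropoxy in place of isopropylsulfanyl on a carbonyl carbon gives a number 0.50 log units lower from compound 2 to compound 4 (beyond the scatter), and of the three groups compared at this nitrogen, only the one in compound 2 stands apart from the others. Nothing among the data shown gives a reason for either result.

The compounds shown leave open whether other groups on this nitrogen, such as a tert-butoxycarbonyl or an acetyl, would also stay within the scatter of compound 3 and compound 4. They also leave open whether the change on the aromatic carbon, seen as a number 0.40 log units higher from compound 1 to compound 3 (beyond the scatter), would be of the same size with isopropoxycarbonyl on the nitrogen.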